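A Sulfonyl Cap Tested for Cell Toxicity

The compounds below may be only part of what the source reports. "The series", "measured", "known", "first", "only" and "open" are said of these compounds alone.

Compound 1 `CC(C)(C)C(=O)N1C[C@H](NC(=O)c2ccc(-n3ccccc3=O)cc2)[C@H](NC(=O)c2ccc(Cl)s2)C1` was examined in an ADME assay on HEK293 cells (Homo sapiens) for cytotoxicity; on this read-out lower numbers stand for stronger inhibition and higher numbers for weaker inhibition. In this assay compound 1 gives only a limit, > 100000 nM. Two close relatives differ from it solely in the group on the ring nitrogen. Compound 2 `O=C(N[C@H]1CN(C(=O)C2CC2)C[C@H]1NC(=O)c1ccc(Cl)s1)c1ccc(-n2ccccc2=O)cc1` likewise gives a limit, > 100000 nM. Compound 3 `COCCOC(=O)N1C[C@H](NC(=O)c2ccc(-n3ccccc3=O)cc2)[C@H](NC(=O)c2ccc(Cl)s2)C1` also gives a limit, > 100000 nM. Because all three sit at the limit of > 100000 nM in this assay, at which 3 of the 3 values shown sit, none of the steps among them can be sized: a step that the two limits leave unreadable from compound 1 to compound 2, a step that the two limits leave unreadable from compound 1 to compound 3 and a step that the two limits leave unreadable from compound 2 to compound 3.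

Compound 4 `CS(=O)(=O)N1C[C@H](NC(=O)c2ccc(-n3ccccc3=O)cc2)[C@H](NC(=O)c2ccc(Cl)s2)C1` has not yet been measured. It changes the same position once more: methylsulfonyl in place of (tert-butyl)carbonyl on an amine nitrogen in a ring. The three measured steps are the only ones that bear on this change, and every one of them is unreadable, so no step beyond the usual scatter is expected in this assay; the step that the limit leaves unreadable from compound 1 to compound 4 is expected to stay unreadable. Compound 4 is therefore expected to give 150000 nM, within 60000 nM to 400000 nM, most likely again as a limit.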

Compound 4, half-maximal inhibitory concentration: > 100000 nM
Compound 4 ended at the assay's limit; the forecaster's own chance of this, stated with the estimate: 85%; the middle value does not contradict the limit.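

Compound 4 also gives only a limit, so its steps from compound 1, compound 2 and compound 3 cannot be read: the limit of > 100000 nM in this assay, at which 4 of the 4 values shown sit.

The compounds shown leave open whether these four groups on the amine nitrogen in the ring differ at all in this assay.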